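From 4-methylpiperazin-1-yl to dipropylamino: what to expect of compound 3

The compounds below may be only part of what the source reports. "The series", "measured", "known", "first", "only" and "open" are said of these compounds alone.

Measured so far in a toxicity assay (L6 cells) for inhibition, with Rattus norvegicus as the target, read by resazurin assay, with a stated time of 70 h; on this read-out lower numbers stand for stronger inhibition and higher numbers for weaker inhibition:
compound 1 (`CN1CCN(CC(=O)N2CCN(c3ccnc4cc(Cl)ccc34)CC2)CC1`): 79800 nM
compound 2 (`O=C(CN1CCCCC1)NCCNc1ccnc2cc(Cl)ccc12`): 23700 nM

For the measured compounds named here, of these two numbers, the one for compound 1 is the higher, and the gap to compound 2 lies beyond the usual scatter. The two compounds do not differ in one place only, so no single structural change can be read from them. Compound 3 (`CCCN(CCC)CC(=O)N1CCN(c2ccnc3cc(Cl)ccc23)CC1`) has not yet been measured. It keeps the core of compound 1 and carries dipropylamino in place of 4-methylpiperazin-1-yl on a saturated chain carbon bound to a carbonyl carbon. The evidence for what this change will do is thin. Going by the values given here, compound 1 sits at the top of the small range seen so far, and the only other number, from compound 2 (23700 nM), is lower, so a fall seems likelier than a rise. In this assay a moderate move to a lower number is expected, an estimated step of a 4.0-fold lower number from compound 1 to compound 3 (0.60 log units; beyond the scatter) that would probably lie beyond the scatter. Compound 3 is estimated at 20000 nM (expected range 7000 nM to 55000 nM).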

Compound 3, half-maximal inhibitory concentration: 70500 nM
The estimate for compound 3 lay 3.5-fold (0.55 log units) below the measured number; measured number above the stated range.
By their numbers in this assay, from the lowest: compound 2; then compounds 3 and 1 (each within the scatter of the next).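

In this assay, placing dipropylamino in place of 4-methylpiperazin-1-yl on a saturated chain carbon bound to a carbonyl carbon gives a 1.1-fold lower number from compound 1 to compound 3 (0.05 log units; within the scatter) and so stays within the scatter. For the compounds shown here, this is the first comparison that isolates a single place, and it shows that the six-membered ring of the leaving group can be exchanged for an open group with no ring and the same number of heavy atoms without a difference that this read-out can separate from repeat-to-repeat variation. No supporting measurement is available that would explain this result.

Still open, as far as these compounds go, is whether a smaller amine such as dimethylamino, a morpholin-4-yl ring or a carboxylic acid at this same place would give a step beyond the scatter, or whether this position accommodates those groups as it does dipropylamino. Also open, from the compounds shown here alone, is whether dipropylamino would give a comparable step on the different framework of compound 2, since a single exchange on the core of compound 1 says nothing about that second setting.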